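Phenyl for 2,5-dimethoxyphenyl on the shared core

The source may report more compounds than this note shows. Statements on the series, on what has been measured and on what is new or still open speak of the compounds shown alone.

In an ADME assay on KB cells (Homo sapiens) for cytotoxicity, read by MTT assay, with a stated time of 72 h (on this read-out higher numbers stand for weaker inhibition and lower numbers for stronger inhibition), compound 1 (`COc1ccc(OC)c(C2=C(c3cc(OC)c(OC)c(OC)c3)C(=O)CC2O[SiH2]C(C)(C)C)c1`) gives 10 ug/mL and compound 2 (`COc1ccc(C2=C(c3cc(OC)c(OC)c(OC)c3)C(=O)C(O[SiH2]C(C)(C)C)C2)cc1`) gives 7 ug/mL within the scatter of each other. Compound 3 (`COc1cc(C2=C(c3ccccc3)C(O[SiH2]C(C)(C)C)CC2=O)cc(OC)c1OC`) carries phenyl in place of 2,5-dimethoxyphenyl on a double-bonded ring carbon of the core of compound 1 (phenyl in place of 2,5-dimethoxyphenyl on a double-bonded ring carbon). Among the compounds with values here, no measured pair isolates this change, so nothing beyond the scatter is expected in this assay and no direction is favoured. The expected size of no change at the digits printed from compound 1 to compound 3 (within the scatter) stays within the scatter. The estimate for compound 3 is 10 ug/mL (expected range 4 ug/mL to 30 ug/mL).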

Compound 3, half-maximal inhibitory concentration: > 100 ug/mL
Compound 3: no number, only a limit; the forecaster's own chance of this, stated with the estimate: 15%; at least 10-fold (1.00 log units) between middle value and limit.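

At the double-bonded ring carbon of the shared core, the 2,5-dimethoxyphenyl group is not interchangeable with phenyl in this assay, where this one change gives an at least 10-fold higher number from compound 1 to compound 3 (1.00 log units; beyond the scatter). Compound 3 gives > 100 ug/mL, which is a limit of the assay and not a number. The step therefore rests on that limit: the limit of > 100 ug/mL in this assay, at which 1 of the 3 values shown sits.

The compounds shown leave open whether a single methoxy group on the phenyl ring would be enough to keep the value of compound 1. Also open, from the compounds shown here alone, is how a hydroxyl or an amine would behave in place of the methoxy groups.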